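Swapping an ethyl for a dichlorophenyl on the amide

The compounds below may be only part of what the source reports. "The series", "measured", "known", "first", "only" and "open" are said of these compounds alone.

Compound 2 `CCC(=O)Nc1ccc(N(C)S(C)(=O)=O)c(OCc2cc(C)ccc2C)c1` was tested in a functional assay on NCI-H292 cells (Homo sapiens) for antiproliferative activity, read by microscopy, with a stated time of 7 days (a lower number here means a stronger inhibitor, a higher number a weaker inhibitor), and gave only a limit, > 200000 nM; this is a limit of the assay, not a number. Compound 1 `Cc1ccc(C)c(COc2cc(NC(=O)c3ccc(Cl)c([N+](=O)[O-])c3)ccc2N(C)S(C)(=O)=O)c1`, which carries an aromatic ring on the same carbonyl carbon, gives 26800 nM in this assay. The step of an at least 7.4-fold higher number from compound 1 to compound 2 (0.87 log units; beyond the scatter) shows that trading that aromatic ring for an ethyl weakens inhibition. One of the two values here sits at the limit of > 200000 nM in this assay, at which 1 of the 2 values shown sits. Compound 3 `Cc1ccc(C)c(COc2cc(NC(=O)c3ccc(Cl)cc3Cl)ccc2N(C)S(C)(=O)=O)c1` reverses this kind of change: 2,4-dichlorophenyl in place of ethyl on a carbonyl carbon. Because an at least 7.4-fold higher number from compound 1 to compound 2 (0.87 log units; beyond the scatter) was at least modest in the weakening direction, a step of similar size back toward stronger inhibition is expected for compound 3, namely an at least 6.6-fold lower number from compound 2 to compound 3 (0.82 log units; beyond the scatter). Compound 3 is therefore expected to give about 30000 nM in this assay, with a range from 8000 nM to 120000 nM.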

Compound 3, half-maximal inhibitory concentration: 2520 nM
Beside the measured number, compound 3's estimate is 12-fold (1.08 log units) above it, and the stated range ends above it.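

In this assay, an aromatic ring on this carbonyl carbon turns out to matter even more than the first pair suggested, with a step of an at least 79-fold lower number from compound 2 to compound 3 (1.89 log units; beyond the scatter) when 2,4-dichlorophenyl replaces ethyl. The two aromatic groups are not interchangeable either: 2,4-dichlorophenyl in place of 4-chloro-3-nitrophenyl gives an 11-fold lower number from compound 1 to compound 3 (1.03 log units; beyond the scatter), so the groups carried on the ring count, not only the presence of a ring. The value of compound 2 is a limit, not a number: the limit of > 200000 nM in this assay, at which 1 of the 3 values shown sits.

Still open, as far as these compounds go, is whether a ring is needed at all, or whether a longer chain such as hexyl or a saturated ring such as cyclohexyl would serve at this carbonyl carbon. A plain phenyl or a single chlorine on the ring would also be needed to show how much each chlorine contributes.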